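A few compounds are considered here, and "the series" means these few. Any claim that something is new, unique, unknown or untested is made for them only; others in the source may bear on it.

Measured compounds in a functional assay on PC-3 cells (Homo sapiens) for cytotoxicity, read by MTT assay, with a stated time of 48 h; a lower number here means a stronger inhibitor, a higher number a weaker inhibitor:
compound 1, `COc1cc(C(=O)C2Sc3nnc(-c4cc(OC)c(OC)c(OC)c4)n3NC2c2ccco2)cc(OC)c1OC`, 52200 nM;
compound 2, `COc1cc(-c2nnc3n2NC(c2ccco2)C(C(=O)c2ccc(F)cc2)S3)cc(OC)c1OC`, 27700 nM.
Compound 3, `COc1ccc(C(=O)C2Sc3nnc(-c4cc(OC)c(OC)c(OC)c4)n3NC2c2ccco2)cc1`, is reported in this assay only as a limit, > 100000 nM; this is the limit of the assay at which one of the three values sits (the limit of > 100000 nM in this assay, at which 1 of the 3 values shown sits).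

Compound 2 holds the lowest of the two numbers shown, but the nearest compound is compound 1, and the step of a 1.9-fold lower number from compound 1 to compound 2 (0.28 log units; within the scatter) stays within the scatter, so no order between compound 1 and compound 2 can be claimed. Compound 3 sits at a limit.

Compound 4, `COc1cc(-c2nnc3n2NC(c2ccco2)C(C(=O)c2ccco2)S3)cc(OC)c1OC`, has not yet been measured. Among the compounds with values here, its single difference from compound 2 is furan-2-yl in place of 4-fluorophenyl on a carbonyl carbon; cut one bond further out, the change reads (4-fluorophenyl)carbonyl to (furan-2-yl)carbonyl.

The measured steps that touch this carbonyl-bound group are a 1.9-fold lower number from compound 1 to compound 2 (0.28 log units; within the scatter), an at least 1.9-fold higher number from compound 1 to compound 3 (0.28 log units; that floor lies within the scatter) and an at least 3.6-fold higher number from compound 2 to compound 3 (0.55 log units; beyond the scatter). Only the last one, where methoxy replaces fluoro on an aromatic carbon, lies beyond the scatter, and it runs toward weaker inhibition. Within the data shown here, no measured step exchanges the whole aryl for a five-membered heteroaryl, so the size of the change to furan-2-yl is not anchored. A small to modest loss, or no change beyond the scatter, is the expectation.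

Compound 4 is therefore estimated at 40000 nM in this assay, within 15000 nM to 100000 nM, which means an expected step of a 1.4-fold higher number from compound 2 to compound 4 (0.16 log units; within the scatter).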

Compound 4, half-maximal inhibitory concentration: 58300 nM
Compound 4: middle estimate off by 1.5-fold (0.16 log units), on the low side; the range from low to high includes it.
By their numbers in this assay, from the lowest: compounds 2, 1 and 4 (each within the scatter of the next, the first and the last beyond it). At a limit, above all of these: compound 3.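

In this assay, only substituted phenyl groups on this carbonyl carbon had been compared until now, and the exchange of a whole aryl for a five-membered heteroaryl gives a 2.1-fold higher number from compound 2 to compound 4 (0.32 log units; beyond the scatter) as a modest loss beyond the scatter. The exchange from the 3,4,5-trimethoxyphenyl group gives a 1.1-fold higher number from compound 1 to compound 4 (0.05 log units; within the scatter) and stays within the scatter, so furan-2-yl and that group cannot be ordered, and the six-membered aromatic ring is not needed to stay at that level, while the 4-fluorophenyl group keeps its edge over furan-2-yl alone. The step of an at least 1.7-fold lower number from compound 3 to compound 4 (0.23 log units; that floor lies within the scatter) starts from a limit of the assay, its floor lies within the scatter, and it sets no order between furan-2-yl and 4-methoxyphenyl: the limit of > 100000 nM in this assay, at which 1 of the 4 values shown sits.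

Open, going by these compounds, is whether thiophen-2-yl, a pyridine ring or a saturated group such as cyclohexyl on this carbonyl carbon would move the number beyond the scatter in either direction. Also open is how much the furan-2-yl and 3,4,5-trimethoxyphenyl groups on the shared core contribute, since both stay constant across the compounds shown and no step tests an amine or a carboxylic acid in their place.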